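Amide substituent change on a catechol diether benzamide

The compounds below may be only part of what the source reports. "The series", "measured", "known", "first", "only" and "open" are said of these compounds alone.

Going by the values given here, compound 3 `COc1ccc(C(=O)Nc2cccnc2)cc1OC1CCCC1` is the second highest of the three numbers known in an assay on isolated protein for inhibition of phosphodiesterase 4A (Sus scrofa); a lower number here means a stronger inhibitor, a higher number a weaker inhibitor: compound 3 gives 550 nM. Its nearest neighbour is compound 2 `COc1ccc(C(=O)Nc2c(F)cccc2F)cc1OC`, which gives 900 nM, a gap within the scatter. Furthest from it stands compound 1 `COc1ccc(C(=O)Nc2c(C)cccc2Cl)cc1OC1CCCC1`, which gives 100 nM; the step of a 5.5-fold higher number from compound 1 to compound 3 (0.74 log units; beyond the scatter) is the only measured change on the amide-type nitrogen and is beyond the scatter, showing that this position matters.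

Compound 4 `COc1ccc(C(=O)NC2(C)C=C(C)ON2)cc1OC1CCCC1` differs from compound 3 in exactly that place: a group of 7 heavy atoms (5 carbon, 1 nitrogen, 1 oxygen; one five-membered non-aromatic ring with 2 hetero atoms) in place of a group of 6 heavy atoms (5 carbon, 1 nitrogen; one six-membered aromatic ring with 1 hetero atom), on an amide-type nitrogen. The group that enters carries a hydrogen-bond donor, a second hydrogen-bond acceptor, and a non-aromatic ring in place of an aromatic one, so the pair is not closely mirrored by any measured step. Among the compounds with values here, the one bearing step, from compound 1 to compound 3, runs from an aromatic carbocycle to an aromatic heterocycle and weakened inhibition by a modest amount. Losing the aromatic ring altogether is expected to weaken it further, by a step of similar or slightly smaller size. Compound 4 is therefore expected to give 1500 nM, with a range from 500 nM to 5000 nM, corresponding to an expected step of a 2.7-fold higher number from compound 3 to compound 4 (0.44 log units; beyond the scatter).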

Compound 4, half-maximal inhibitory concentration: 450 nM
Beside the measured number, compound 4's estimate is 3.3-fold (0.52 log units) above it; measured number outside the range, below it.
By their numbers in this assay, from the lowest: compound 1; then compounds 4, 3 and 2 (each within the scatter of the next).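

In this assay the change reads as a 1.2-fold lower number from compound 3 to compound 4 (0.09 log units; within the scatter) and so shows that the amide-type nitrogen can carry a five-membered non-aromatic ring with 2 hetero atoms in place of pyridin-3-yl with no difference that can be told from the scatter; among these compounds, an aromatic ring on this nitrogen is not needed to give a number of this size. The 2-chloro-6-methylphenyl group of compound 1 remains the one that stands apart, with a 4.5-fold higher number from compound 1 to compound 4 (0.65 log units; beyond the scatter) now joining the earlier step to pyridin-3-yl, so two quite different groups both give higher numbers than it does. No available measurement accounts for how such unlike groups come to give numbers within the scatter of each other.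

The compounds shown leave open whether the lower number of compound 1 needs both its chlorine and its methyl group, which a plain phenyl or a 2-chlorophenyl group on the same nitrogen would help to settle. They also leave open whether a ring is needed here at all, a question that an open chain such as n-butyl would address.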